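Removing the chloro from the acetamide of compound 3

The source may hold more compounds than are shown below. What is called first, only, known or untested is meant among the compounds shown, and "the series" means these compounds.

Compound 3 `CNC(=O)CSc1nc2ccc(NC(=O)CCl)cc2s1` shows the lowest number among the three measured compounds in a functional assay on MCF7 cells (Homo sapiens) for cytotoxicity, read by MTT assay, with a stated time of 48 h (on this read-out lower numbers stand for stronger inhibition and higher numbers for weaker inhibition), giving 5000 nM. Compound 1 `CC(=O)Nc1ccc2nc(SCC(=O)NCc3ccccc3)sc2c1` gives 17600 nM, and compound 2 `COc1ccc(CNC(=O)CSc2nc3ccc(NC(C)=O)cc3s2)cc1` gives 20500 nM; the gap from compound 3 to each of them lies beyond the scatter. Compound 4 `CNC(=O)CSc1nc2ccc(NC(C)=O)cc2s1` differs from compound 3 by one change: hydrogen in place of chloro on a saturated chain carbon bound to a carbonyl carbon, so that the ((chloromethyl)carbonyl)amino group becomes an acetamido group. For the measured compounds named here, the only measured step, a 1.2-fold higher number from compound 1 to compound 2 (0.07 log units; within the scatter), concerns a methoxy on an aromatic carbon and does not touch this part of the molecule, so no measured step bears on the change directly. Compounds 1 and 2 carry the acetamido group that compound 4 gains, but they also differ elsewhere, so they give only a loose guide. On that guide compound 4 is expected to give a higher number than compound 3, a step of about a 3.0-fold higher number from compound 3 to compound 4 (0.48 log units; beyond the scatter). Compound 4 is therefore estimated at 15000 nM, within a range from 5000 nM to 40000 nM.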

Compound 4, half-maximal inhibitory concentration: > 100000 nM
Compound 4 ended at the assay's limit; the forecaster's own chance of this, stated with the estimate: 10%; at least 6.6-fold (0.82 log units) between middle value and limit.
By their numbers in this assay, from the lowest: compound 3; then compounds 1 and 2 (each within the scatter of the next). At a limit, above all of these: compound 4.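

In this assay the chloro on this saturated chain carbon bound to a carbonyl carbon turns out to matter far more than compounds 1 and 2 could show, since hydrogen in its place gives an at least 20-fold higher number from compound 3 to compound 4 (1.30 log units; beyond the scatter) in this series. Compound 4 gives > 100000 nM which is a limit of the assay and not a number: the limit of > 100000 nM in this assay, at which 1 of the 4 values shown sits. The group on the amide nitrogen also counts while the acetamido group stays, with hydrogen in place of phenyl giving an at least 5.6-fold higher number from compound 1 to compound 4 (0.75 log units; beyond the scatter) and hydrogen in place of 4-methoxyphenyl giving an at least 4.8-fold higher number from compound 2 to compound 4 (0.68 log units; beyond the scatter) on the same read-out.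

Going by these compounds, it remains open whether the chloro is special, or whether a bromo, a hydroxy or an amine on that carbon would keep the number of compound 3. Also open, on these data alone, is how the chloromethyl carbonyl group behaves alongside a phenyl or 4-methoxyphenyl on the amide side.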